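The source may report more compounds than this note shows. Statements on the series, on what has been measured and on what is new or still open speak of the compounds shown alone.

Compound 1 `O=[N+]([O-])c1c(CS(=O)(=O)c2ccccc2)nc2c(C#Cc3ccccc3F)cc(Cl)cn12` is measured in an ADME assay on HepG2 cells (Homo sapiens) for cytotoxicity, read by MTT assay, with a stated time of 72 h; on this read-out lower numbers stand for higher toxicity in this test and higher numbers for lower toxicity in this test; compound 1 gives > 3900 nM, a limit of the assay.
Compound 2 `O=[N+]([O-])c1c(CS(=O)(=O)c2ccccc2)nc2c(C#Cc3cccnc3)cc(Cl)cn12` gives > 3900 nM in this assay, again a limit.
Compound 3 `O=[N+]([O-])c1c(CS(=O)(=O)c2ccccc2)nc2c(C#CCCO)cc(Cl)cn12` gives > 125000 nM in this assay, also a limit.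

Compound 1 therefore stands only at a limit: two of the three values sit at the limit of > 3900 nM in this assay, at which 2 of the 3 values shown sit, the third at the limit of > 125000 nM in this assay, at which 1 of the 3 values shown sits. Compound 4 `O=[N+]([O-])c1c(CS(=O)(=O)c2ccccc2)nc2c(C#CC3(O)CCCCC3)cc(Cl)cn12` differs from compound 1 by 1-hydroxycyclohexyl in place of 2-fluorophenyl on a triple-bonded carbon. Among the measured compounds shown here, the steps that bear on it, a step that the two limits leave unreadable from compound 1 to compound 3 and a step that the two limits leave unreadable from compound 1 to compound 2, are both unreadable between limits, so no direction beyond the scatter can be expected in this assay. Compound 4 is estimated at 12000 nM, with a range from 3900 nM to 125000 nM, most likely reported as a limit; the expected step is a step that the limit leaves unreadable from compound 1 to compound 4.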

Compound 4, half-maximal cytotoxic concentration: > 25000 nM
Compound 4: a limit, no number; the forecaster's own chance of this, stated with the estimate: 75%; middle value at least 2.0-fold (0.31 log units) away from the limit.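

Among the compounds shown here, compound 4, like compound 1, compound 2 and compound 3, stands only at a limit in this assay, so no step among them can be read. As far as these compounds go, whether their groups on the triple-bonded carbon differ at all in this test stays open.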